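The source may hold more compounds than are shown below. What is called first, only, known or untested is meant among the compounds shown, and "the series" means these compounds.

Of the compounds shown here, three sharing one core have been measured in an in vitro ADME assay on microsomes from liver (Homo sapiens) for pharmacokinetics, read by LC-MS, with a stated time of 10 min, tested at 1 uM; on this read-out lower numbers stand for slow clearance and higher numbers for fast clearance. Compound 1 `CN1C[C@H](C(=O)Nc2ccc(F)cc2)[C@@H](c2ccc(/C=C/C(=O)Nc3ccccc3N)cc2)C1` gives 5 mL/min/kg. Compound 2 `CN1C[C@H](C(=O)Nc2ccc(Br)cc2)[C@@H](c2ccc(/C=C/C(=O)Nc3ccccc3N)cc2)C1` gives 3 mL/min/kg, the lowest of the three numbers, although the step of a 1.7-fold lower number from compound 1 to compound 2 (0.22 log units; within the scatter) is within the scatter, so compound 1 and compound 2 cannot be told apart. Within the data shown here, compound 3 `CN1C[C@H](C(=O)Nc2ccc(F)cc2F)[C@@H](c2ccc(/C=C/C(=O)Nc3ccccc3N)cc2)C1` gives 12 mL/min/kg, and the step of a 4.0-fold higher number from compound 2 to compound 3 (0.60 log units; beyond the scatter) is the only one from compound 2 that lies beyond the scatter; the step of a 2.4-fold higher number from compound 1 to compound 3 (0.38 log units; beyond the scatter) points the same way.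

Compound 4 `CN1C[C@H](C(=O)Nc2cccnc2)[C@@H](c2ccc(/C=C/C(=O)Nc3ccccc3N)cc2)C1` differs from compound 2 in a single place: pyridin-3-yl in place of 4-bromophenyl on an amide-type nitrogen. Among the measured compounds shown here, the step that bears most on this change is the one from compound 2 to compound 3, where swapping the group on the amide-type nitrogen raised the number, but no measured compound carries a ring with a hetero atom there, so that step is only a loose guide. A modest rise is therefore expected, and the estimated step of a 2.0-fold higher number from compound 2 to compound 4 (0.30 log units; within the scatter) gives compound 4 an expected clearance of 6 mL/min/kg, with a likely range from 3 mL/min/kg to 14 mL/min/kg.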

Compound 4, clearance: 10 mL/min/kg
For compound 4 the middle estimate is 1.7-fold (0.22 log units) below the measured one; the range from low to high includes it.
By their numbers in this assay, from the lowest: compounds 2, 1, 4 and 3 (each within the scatter of the next, the first and the last beyond it).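

Pyridin-3-yl is the first ring with a hetero atom on this amide-type nitrogen, and in this assay putting it in place of 4-bromophenyl gives a clear shift (a 3.3-fold higher number from compound 2 to compound 4 (0.52 log units; beyond the scatter)). The other two comparisons stay within the scatter (a 1.2-fold lower number from compound 3 to compound 4 (0.08 log units; within the scatter); a 2.0-fold higher number from compound 1 to compound 4 (0.30 log units; within the scatter)), so compound 4 cannot be told apart from compound 1 or compound 3, and only compound 2 stands clearly apart from it. Nothing available explains this shift.

Going by these compounds, it remains open whether the hetero atom itself matters here, or whether the result mainly reflects the loss of the bromo group. A pyrimidinyl ring, a 4-chlorophenyl group or a saturated cyclohexyl group on the same nitrogen could help separate these possibilities.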